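Aryl Nitrile Swap on an Amidoxime Series

This account rests on a few compounds, and the source may have more. Where it says the series, first, only, none or still open, it means among the compounds named here.

In an assay for inhibition of Indoleamine 2,3-dioxygenase 1 (Homo sapiens), read by fluorescence, with a stated time of 1 h (on this read-out higher numbers stand for weaker inhibition and lower numbers for stronger inhibition), the three measured compounds are: compound 1 `NS(=O)(=O)CC(=O)NCCSc1nonc1/C(=N/O)Nc1ccc(F)c(C(F)F)c1`, 73 nM; compound 2 `CC(C)(O)CC(=O)NCCSc1nonc1/C(=N/O)Nc1ccc(F)c(C(F)F)c1`, 140 nM; compound 3 `CS(=O)(=O)CC(=O)NCCSc1nonc1/C(=N/O)Nc1ccc(F)c(C(F)F)c1`, 100 nM.

Compound 1 gives the lowest of these three numbers, but its steps to the others, a 1.9-fold higher number from compound 1 to compound 2 (0.28 log units; within the scatter) and a 1.4-fold higher number from compound 1 to compound 3 (0.14 log units; within the scatter), both fall within the scatter, so no order among them is claimed. Compound 4 `N#Cc1cc(N/C(=N\O)c2nonc2SCCNC(=O)CS(N)(=O)=O)ccc1F` alters the aryl end instead: cyano in place of difluoromethyl on an aromatic carbon. For the measured compounds named here, none of the measured steps touches this ring; each exchanges the group on the chain carbon bound to the carbonyl carbon, and all lie within the scatter. There is thus no measured guide for the aryl change, and the expected step, a 1.2-fold higher number from compound 1 to compound 4 (0.09 log units; within the scatter), is small and of no firm direction. Compound 4 is estimated at 90 nM, within 35 nM to 250 nM.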

Compound 4, half-maximal inhibitory concentration: 150 nM
The estimate for compound 4 lay 1.7-fold (0.22 log units) below the measured number, and the stated range covers the measured number.
By their numbers in this assay, from the lowest: compounds 1, 3, 2 and 4 (each within the scatter of the next, the first and the last beyond it).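

For the compounds shown here, exchanging 3-(difluoromethyl)-4-fluorophenyl for 3-cyano-4-fluorophenyl gives a 2.1-fold higher number from compound 1 to compound 4 (0.31 log units; beyond the scatter) and so provides the first step in this set beyond the scatter, though a modest one. The earlier steps shown here, all on the chain carbon bound to the carbonyl carbon, stayed within the scatter. No measurement at hand bears on why the number rose.

One replacement cannot show how trifluoromethyl, chloro or methyl would read on this aromatic carbon. Going by these compounds, it also remains open whether the cyano change would give a similar step on the chain of compound 2 or compound 3.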